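Changing the Ring on the Saturated Carbon of Compound 1

The compounds below may be only part of what the source reports. "The series", "measured", "known", "first", "only" and "open" are said of these compounds alone.

Compound 1 `CC1=C(C(=O)Nc2ccc(Br)cc2)C(c2ccc(Cl)cc2Cl)N=C(SCc2ccccc2Cl)N1`: 5.7%
Compound 2 `CC1=C(C(=O)Nc2ccc(Br)cc2)C(c2ccc(Cl)cc2Cl)N=C(SCc2ccc(F)cc2)N1`: 7.7%

In a functional assay on the whole organism (artery, strain albino) with Rattus norvegicus as the target, with a stated time of 30 min, at a dose of 10 mg/kg by the oral route (a lower number here means less inhibition, a higher number more inhibition at the dose given (going by the name of the read-out)), compound 1 gives 5.7%, and compound 2 gives 7.7%; the two stand within the scatter of each other, so their numbers count as level. Going by the values given here, the one measured step, a number 2 percentage points higher from compound 1 to compound 2 (within the scatter), changes a group elsewhere and stays within the scatter. Compound 3 `COc1ccc(C2N=C(SCc3ccccc3Cl)NC(C)=C2C(=O)Nc2ccc(Br)cc2)cc1` differs from compound 1 in another place: 4-methoxyphenyl in place of 2,4-dichlorophenyl on a saturated ring carbon. Among the compounds with values here, no measured step touches that saturated ring carbon, so the step is expected to stay within the scatter, a number 1.3 percentage points higher from compound 1 to compound 3 (within the scatter). Compound 3 is therefore estimated at 7%, ranging from 0% to 20%.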

Compound 3, a percentage reported as inhibition, in the whole organism at one dose (the size of the read-out at that dose, not a potency): 4.6%
Compound 3: middle estimate off by 2.4 percentage points, on the high side, within the range that was stated.
By their numbers in this assay, from the lowest: compounds 3, 1 and 2 (each within the scatter of the next).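

Going by these compounds alone, at the saturated ring carbon, the change to 4-methoxyphenyl in place of 2,4-dichlorophenyl in this assay gives a number 1.1 percentage points lower from compound 1 to compound 3 (within the scatter), the first measured step at this position. Replacing the two chlorine atoms with a methoxy group, at the same heavy-atom count, therefore leaves the two numbers level, as the earlier step elsewhere on the molecule did. No evidence on hand bears on this result. The compounds shown leave open whether an amine or a carboxylic acid on this ring, or a longer chain in its place, would give a step beyond the scatter.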